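This account rests on a few compounds, and the source may have more. Where it says the series, first, only, none or still open, it means among the compounds named here.

Working notes on the series in a toxicity assay (L6 cells) for cytotoxicity, with Rattus norvegicus as the target, read by resazurin assay, with a stated time of 70 h; on this read-out higher numbers stand for weaker inhibition and lower numbers for stronger inhibition. Compound 1 (`Cn1c(-c2ccc(C(=N)N)cc2)nc2cc(C(=N)N)ccc21`) gives > 169000 nM, which is a limit of the assay and not a number. Compound 2 (`CCCn1c(-c2ccc(C(=N)N)cc2)nc2cc(C(=N)N)ccc21`) gives > 137000 nM, which is also a limit. For the measured compounds named here, compound 2 therefore has no numerical position, and the only other value available is a limit as well. Going by the values given here, the single measured step is a step that the two limits leave unreadable from compound 1 to compound 2, so it offers no size to carry forward.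

Compound 3 (`N=C(N)c1ccc(-c2nc3cc(C(=N)N)ccc3n2C2CCCCC2)cc1`) keeps the shared core and changes one group: cyclohexyl in place of propyl on an aromatic nitrogen. In words, this is cyclohexyl in place of propyl on an aromatic nitrogen. Among the compounds with values here, the only earlier change at this nitrogen is the step between compound 1 and compound 2, and it cannot be sized. No step beyond the scatter is therefore expected in this assay, and no direction can be assigned. Another limit is the most likely report. The estimated step is an at least 1.1-fold lower number from compound 2 to compound 3 (0.05 log units; that floor lies within the scatter). For compound 3 the expected value is 120000 nM, with an estimated range from 40000 nM to 200000 nM.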

Compound 3, half-maximal inhibitory concentration: > 162000 nM
Compound 3 ended at the assay's limit (the forecaster's own chance of this, stated with the estimate: 65%); middle value at least 1.3-fold (0.13 log units) away from the limit.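

In this assay compound 3 gives > 162000 nM, which is a limit of the assay and not a number. For the compounds shown here, the values of compound 1, compound 2 and compound 3 are all limits, so no step among them can be read. The compounds shown leave open whether the group on the aromatic nitrogen alters this read-out at all.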